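The source may hold more compounds than are shown below. What is called first, only, known or untested is meant among the compounds shown, and "the series" means these compounds.

Compound 1 `C/C(=N\CC(C)C)c1c(O)c2ccccc2oc1=O` is tested in an assay on isolated protein for inhibition of myosin-2 (Bos taurus), read by spectrophotometry, with a stated time of 24 min (on this read-out lower numbers stand for stronger inhibition and higher numbers for weaker inhibition), and gives 34000 nM. Compound 2 `CCC(C)/N=C(\C)c1c(O)c2ccccc2[nH]c1=O` reaches only a limit of the assay in this assay, >= 100000 nM. Compound 3 `CCC/C(=N\Cc1ccccc1)c1c(O)c2ccccc2oc1=O` also returns a limit in this assay, >= 100000 nM. Compound 2 thus stands at the limit of >= 100000 nM in this assay, at which 2 of the 3 values shown sit, so that only compound 1 supplies an actual number among the three measured compounds.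

Compound 4 `C/C(=N\CC(C)C)c1c(O)c2ccccc2[nH]c1=O` differs from compound 2 by isobutyl in place of sec-butyl on a double-bonded nitrogen. For the measured compounds named here, no pair of measured compounds differs in only this way, so no measured step tells how large an effect to expect. Going by the values given here, compound 1 also carries isobutyl on the double-bonded nitrogen and gives a number, yet its core differs from that of compound 2 as well, so the two values show only that the isobutyl compound with the other core is measurable.

Compound 4 is expected to give about 80000 nM, within a range from 30000 nM to 200000 nM. The step of an at least 1.2-fold lower number from compound 2 to compound 4 (0.09 log units; that floor lies within the scatter) is thus estimated to be small, and likely to remain within the scatter or to yield only a limit again.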

Compound 4, half-maximal inhibitory concentration: >= 100000 nM
Compound 4 gave a limit, no number; the forecaster's own chance of this, stated with the estimate: 50%; middle value at least 1.2-fold (0.09 log units) from the limit.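

For the compounds shown here, compound 2 and compound 4 both return only a limit in this assay, so no step between them can be read: the limit of >= 100000 nM in this assay, at which 3 of the 4 values shown sit.

The compounds shown leave open whether isobutyl in place of sec-butyl on a double-bonded nitrogen changes inhibition at all on the core of compound 4.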